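The source may report more compounds than this note shows. Statements on the series, on what has been measured and on what is new or still open speak of the compounds shown alone.

Compound 1 `COC(=O)[C@@]1(C)CCC=C2[C@@H]1CC[C@@H](C)[C@]2(C)Cc1c[nH]c2ccccc12` gives 7300 nM in a functional assay on SW1573 cells (Homo sapiens) for inhibition, read by sulforhodamine B assay, with a stated time of 48 h; a lower number here means a stronger inhibitor of growth, a higher number a weaker inhibitor of growth. Going by the values given here, compound 2 `COC(=O)[C@@]1(C)CCC=C2[C@@H]1CC[C@@H](C)[C@]2(C)Cc1c(C)[nH]c2ccccc12` gives 14000 nM, the higher of the two numbers so far, though a 1.9-fold higher number from compound 1 to compound 2 (0.28 log units; within the scatter) stays within the scatter. Compound 3 `COC(=O)[C@@]1(C)CCC=C2[C@@H]1CC[C@@H](C)[C@]2(C)Cc1c(C=O)[nH]c2ccccc12` is not yet measured; it carries formyl in place of methyl on an aromatic carbon. Among the compounds with values here, the only measured step bearing on this change is the one on the same aromatic carbon, from methyl in place of hydrogen, and it did not move beyond the scatter. No step beyond the scatter is therefore expected, and no change at the digits printed from compound 2 to compound 3 (within the scatter) is the estimate. Compound 3 is expected to give 14000 nM, between 5000 nM and 40000 nM.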

Compound 3, concentration for 50% growth inhibition: 7900 nM
Estimate against measurement, compound 3: 1.8-fold (0.25 log units) above, and the stated range covers the measured number.
By their numbers in this assay, from the lowest: compounds 1, 3 and 2 (each within the scatter of the next).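

On the aromatic carbon next to the ring nitrogen, a formyl group, which adds a hydrogen-bond acceptor and a double bond, gives no step beyond the scatter in this assay: the reading is a 1.8-fold lower number from compound 2 to compound 3 (0.25 log units; within the scatter). With hydrogen at this carbon as the reference, the reading is a 1.1-fold higher number from compound 1 to compound 3 (0.03 log units; within the scatter), so hydrogen, methyl and formyl are not separated at this position. No measurement at hand accounts for these readings. On these data alone, it remains open whether an amine, a carboxylic acid or a longer chain on this carbon would move the number beyond the scatter.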